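The source may hold more compounds than are shown below. What is called first, only, known or untested is meant among the compounds shown, and "the series" means these compounds.

Measured compounds in a functional assay (aorta) with Oryctolagus cuniculus as the target; a higher number here means a weaker inhibitor, a lower number a stronger inhibitor:
compound 1 `CCO/C(O)=C1\C(C)=NC(C)=C(C(=O)OCCCN2C(=O)c3ccccc3S2(=O)=O)C1c1ccccc1[N+](=O)[O-]`: 2.6 nM
compound 2 `CC1=NC(C)=C(C(=O)OCCCN2C(=O)c3ccccc3S2(=O)=O)C(c2ccccc2[N+](=O)[O-])/C1=C(\O)OC(C)C`: 1.2 nM
compound 3 `CC1=NC(C)=C(C(=O)OCCCN2C(=O)c3ccccc3S2(=O)=O)C(c2ccccc2[N+](=O)[O-])/C1=C(\O)OCC1CCCCO1`: 11.5 nM

Compound 1 gives the second highest of the three numbers in this assay. The nearest neighbour is compound 2, reached by a 2.2-fold lower number from compound 1 to compound 2 (0.34 log units; beyond the scatter), the furthest is compound 3, reached by a 4.4-fold higher number from compound 1 to compound 3 (0.65 log units; beyond the scatter); between those two lies a 9.6-fold higher number from compound 2 to compound 3 (0.98 log units; beyond the scatter). All three measured steps alter only the alkyl portion attached to the oxygen on an unsaturated carbon, and all were modest.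

Compound 4 `CCO/C(O)=C1\C(C)=NC(C)=C(C(=O)OCCCN2C(=O)c3ccccc3S2(=O)=O)C1c1ccccc1Cl` differs from compound 1 at a different site: chloro in place of nitro on an aromatic carbon. Among the compounds with values here, no measured step touches this part of the shared core, so the three steps above give only a sense of how far single changes have moved the number, not a direction for this one. The expectation for compound 4 is therefore a number close to that of compound 1, with a step that may fall within the scatter or be modest in either direction, and with wider uncertainty than the measured steps would suggest.

Compound 4 is estimated at 2.6 nM in this assay, with a range from 0.8 nM to 8.5 nM, which would be expected to correspond to no change at the digits printed from compound 1 to compound 4 (within the scatter).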

Compound 4, half-maximal inhibitory concentration: 3.9 nM
Compound 4: the middle estimate sits 1.5-fold (0.18 log units) below what was measured; the range from low to high includes it.
By their numbers in this assay, from the lowest: compound 2; then compounds 1 and 4 (each within the scatter of the next); then compound 3.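

In this assay, within the data shown here, the exchange of 2-nitrophenyl for 2-chlorophenyl gives a 1.5-fold higher number from compound 1 to compound 4 (0.18 log units; within the scatter), the first reading at this aromatic carbon, ortho to a large group, after steps that altered only the alkyl portion on the oxygen. A nitro group with 3 heavy atoms and 2 hydrogen-bond acceptors can thus give way to a single chlorine with no hydrogen-bond acceptors while compound 1 and compound 4 stay within the scatter of each other, so in this one pair the nitro group is not needed to keep the number in the low range seen for compound 1. Nothing available explains why the two groups read alike in this assay.

The compounds shown leave open whether the same exchange would hold with the isopropyl or (oxan-2-yl)methyl groups of compound 2 and compound 3, since both carry only the nitro group. They also leave open how a methoxy group, a nitrile, a trifluoromethyl group or an amine would read at this same aromatic carbon, and whether a chloro group would read alike on another carbon of that ring.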